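Ethyl for fluoro on the fused ring of compound 2

A few compounds are considered here, and "the series" means these few. Any claim that something is new, unique, unknown or untested is made for them only; others in the source may bear on it.

Measured compounds in a functional assay on CWR22R cells (Homo sapiens) for inhibition; on this read-out higher numbers stand for weaker inhibition and lower numbers for stronger inhibition:
compound 1, `CCn1c(=O)/c(=C2\Sc3ccccc3N2C)s/c1=C\c1ccncc1Nc1ccccc1F`: 300 nM
compound 2, `CCn1c(=O)/c(=C2\Sc3cc(F)ccc3N2C)s/c1=C\c1ccncc1Nc1ccccc1F`: 150 nM

Compound 2 has the lower of the two numbers, and its nearest neighbour is compound 1; the step of a 2.0-fold lower number from compound 1 to compound 2 (0.30 log units; within the scatter), so the two values cannot be told apart on this read-out. Compound 3, `CCc1ccc2c(c1)S/C(=c1/s/c(=C\c3ccncc3Nc3ccccc3F)n(CC)c1=O)N2C`, has not been measured. It differs from compound 2 in one place: ethyl in place of fluoro on an aromatic carbon. Among the measured compounds shown here, the only step measured so far that touches this position is the one from compound 1 to compound 2, in which the fluoro entered in place of hydrogen, and that step stayed within the scatter. For the measured compounds named here, the data give no step involving an ethyl group anywhere on the shared core, so nothing shows a larger effect of this substituent. For compound 3 the step is therefore expected to be small, a 1.3-fold higher number from compound 2 to compound 3 (0.12 log units; within the scatter), with no direction beyond the scatter. The estimated value of compound 3 in this assay is 200 nM, within a range from 70 nM to 600 nM.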

Compound 3, half-maximal inhibitory concentration: 1200 nM
The estimate for compound 3 lay 6.0-fold (0.78 log units) below the measured number; measured number outside the range, above it.
By their numbers in this assay, from the lowest: compounds 2 and 1 (each within the scatter of the next); then compound 3.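

The position on the fused ring is not indifferent to its substituent in this assay as the hydrogen and fluoro pair alone might have suggested, since ethyl gives an 8.0-fold higher number from compound 2 to compound 3 (0.90 log units; beyond the scatter) and a 4.0-fold higher number from compound 1 to compound 3 (0.60 log units; beyond the scatter) and both steps lie beyond the scatter. Replacing either smaller substituent with ethyl therefore weakens inhibition, and compound 3 is the weakest inhibitor of the three, whereas the step between hydrogen and fluoro on this same aromatic carbon remained within the scatter. Nothing available explains why ethyl behaves differently from fluoro and hydrogen at this position, so the result stands as an observation about these three compounds only.

The compounds shown leave open whether the loss begins with a single added carbon, as in a methyl group, and whether it grows with a longer chain such as propyl. They also leave open whether other groups, such as chloro, methoxy or an amine, would stay with hydrogen and fluoro or fall with ethyl, and whether ethyl on another carbon of this ring would give a similar step.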